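The compounds below may be only part of what the source reports. "The series", "measured", "known", "first", "only" and "open" are said of these compounds alone.

Measured compounds:
Compound 1, `Cn1c(-c2ccc(C(=O)NC3CC3)cc2)nnc1C1(c2ccc(Cl)cc2)CCC1`, in an assay on isolated protein for inhibition of 11-beta-hydroxysteroid dehydrogenase type 2 (Homo sapiens) (a lower number here means a stronger inhibitor, a higher number a weaker inhibitor), gives > 4000 nM, which is a limit of the assay rather than a number.
Compound 2, `CC(=O)Nc1ccc(-c2nnc(C3(c4ccc(Cl)cc4)CCC3)n2C)c(Cl)c1`, in this assay gives > 4000 nM, likewise a limit rather than a number.

Compound 2 therefore has no measured position on a scale; all that is known of it is the limit of > 4000 nM in this assay, at which 2 of the 2 values shown sit. Within the data shown here, compound 1 sits at the same limit, so the two compounds cannot be ordered against each other and no step between them can be sized. Compound 3, `Cn1c(-c2ccc(-c3cccnc3)cc2Cl)nnc1C1(c2ccc(Cl)cc2)CCC1`, is not yet measured. It differs from compound 2 in one place: pyridin-3-yl in place of acetamido on an aromatic carbon. Among the measured compounds shown here, no comparable step exists among the measured compounds, so there is no measured guide to the size or direction of this change in this assay; with compound 2 known only as a limit, a step beyond the scatter could only become visible if compound 3 turned into a clear inhibitor. The expectation is no change beyond the scatter, with compound 3 most likely also returned as a limit. Compound 3 is estimated at 8000 nM, within 2000 nM to 30000 nM, an expected step that the limit leaves unreadable from compound 2 to compound 3.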

Compound 3, half-maximal inhibitory concentration: > 4000 nM
Compound 3: only a limit was reported; the forecaster's own chance of this, stated with the estimate: 75%; the middle value does not contradict the limit.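

In this assay compound 3 gives > 4000 nM, which is a limit and not a number. Compound 2 is also known only as a limit, so no step can be read between compound 2 and compound 3. The compounds shown leave open what change, if any, would give a measurable inhibitor, since all share one reading: the limit of > 4000 nM in this assay, at which 3 of the 3 values shown sit.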